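Trifluoromethyl for Methyl on a Free Fatty Acid Receptor Agonist

The compounds below may be only part of what the source reports. "The series", "measured", "known", "first", "only" and "open" are said of these compounds alone.

The two measured compounds share a core that carries a propargylic acid chain and an ether-linked bicyclic headgroup bearing a methyl-substituted phenyl ring. Compound 1 `CC#CC(CC(=O)O)c1ccc(OCc2ccc3nc(-c4ccccc4C)cn3c2)cc1` gives 389 nM in an assay on isolated protein for agonist activity at Free fatty acid receptor 1 (Homo sapiens); on this read-out lower numbers stand for an effect already at smaller amounts and higher numbers for an effect only at larger amounts of compound. Compound 2 `CC#CC(CC(=O)O)c1ccc(OCc2ccn3cc(-c4ccc(C)cc4)nc3c2)cc1` differs in the arrangement of the bicyclic headgroup and in the site of the methyl on the phenyl ring; in this assay compound 2 gives 618 nM, a number that sits within the usual scatter of that of compound 1, so the two compounds cannot be separated on these data.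

Compound 3 `CC#CC(CC(=O)O)c1ccc(OCc2ccn3cc(-c4ccc(C(F)(F)F)cc4)nc3c2)cc1` follows from compound 2 by a single change: trifluoromethyl in place of methyl on an aromatic carbon. Within the data shown here, no step of this kind has been measured, so there is no precedent to draw on. On the two numbers available, the expectation is a small step, if any, with a slight lean toward a lower number that would still fall inside the scatter; the step of a 1.4-fold lower number from compound 2 to compound 3 (0.14 log units; within the scatter) is thus expected to be modest. Compound 3 is expected to give 450 nM, with a range from 150 nM to 1500 nM.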

Compound 3, half-maximal effective concentration: 674 nM
Compound 3: the middle estimate sits 1.5-fold (0.18 log units) below what was measured; the range from low to high includes it.
By their numbers in this assay, from the lowest: compounds 1, 2 and 3 (each within the scatter of the next).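

In this assay, the change from 4-methylphenyl to 4-(trifluoromethyl)phenyl is a 1.1-fold higher number from compound 2 to compound 3 (0.04 log units; within the scatter), so compound 2 and compound 3 cannot be told apart on this read-out. Among these compounds, this is the first single-change comparison, and it shows that, on this aromatic carbon para to a large group, trifluoromethyl can stand in place of methyl without a step that rises above the usual scatter of repeated measurements. Nothing available explains this result or shows how the two groups act at this position.

A single pair cannot show whether this holds for other groups on the same carbon, such as a methoxy group, a chlorine atom, a nitrile or an amine, or whether any of them would produce a step beyond the scatter. It also leaves open whether trifluoromethyl in place of the methyl of compound 1 would behave in the same way, since compound 1 differs from compound 2 in more than one place and the comparison here cannot be carried over to it.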